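The source may hold more compounds than are shown below. What is called first, only, known or untested is meant among the compounds shown, and "the series" means these compounds.

Measured in a functional assay on SF-268 cells (Homo sapiens) for cytotoxicity, read by MTT assay, with a stated time of 3 days; on this read-out higher numbers stand for weaker inhibition and lower numbers for stronger inhibition:
- compound 1 `N#Cc1c(NN)nc(SCc2nc3ccccc3[nH]2)nc1-c1ccccc1`: 2.77 nM
- compound 2 `CNc1nc(SCc2nc3ccccc3[nH]2)nc(-c2ccccc2)c1C#N`: 3.2 nM
- compound 3 `N#Cc1c(NNC(N)=S)nc(SCc2nc3ccccc3[nH]2)nc1-c1ccccc1`: 3.37 nM

The three compounds cannot be ranked on these numbers. Compound 3 stands within the scatter of both others, as shown by a 1.2-fold higher number from compound 1 to compound 3 (0.09 log units; within the scatter) and a 1.1-fold higher number from compound 2 to compound 3 (0.02 log units; within the scatter).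

The next compound is compound 4 `CN1CCN(c2nc(SCc3nc4ccccc4[nH]3)nc(-c3ccccc3)c2C#N)CC1`. The change is a group of 7 heavy atoms (5 carbon, 2 nitrogen; one six-membered non-aromatic ring with 2 hetero atoms) in place of a group of 5 heavy atoms (1 carbon, 3 nitrogen, 1 sulfur; no ring), on an aromatic carbon: a 4-methylpiperazin-1-yl group in place of a group with no common name, on an aromatic carbon ortho to a cyano group.

All three measured steps bear on this change, since each swaps the group in this same place on the shared core. Besides the two steps above, there is a 1.2-fold higher number from compound 1 to compound 2 (0.06 log units; within the scatter). So far, this place has tolerated different groups in this assay without a step beyond the scatter. However, no measured compound has a ring here, so the evidence reaches compound 4 only by extension, and the range is kept wider than the measured steps.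

No step beyond the scatter is expected, and the estimated change is a 1.0-fold higher number from compound 3 to compound 4 (0.02 log units; within the scatter). The estimate for compound 4 is 3.5 nM, with an expected range from 1.5 nM to 9 nM.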

Compound 4, half-maximal inhibitory concentration: 6.9 nM
The estimate for compound 4 lay 2.0-fold (0.29 log units) below the measured number; the measured number falls inside the stated range.
By their numbers in this assay, from the lowest: compounds 1, 2 and 3 (each within the scatter of the next); then compound 4.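

In this assay this place, on an aromatic carbon ortho to a cyano group, now shows steps beyond the scatter, with 4-methylpiperazin-1-yl entering: there is a 2.0-fold higher number from compound 3 to compound 4 (0.31 log units; beyond the scatter) and a 2.2-fold higher number from compound 2 to compound 4 (0.33 log units; beyond the scatter) and a 2.5-fold higher number from compound 1 to compound 4 (0.40 log units; beyond the scatter) and all three are modest. The tolerance seen among the open-chain groups of compounds 1, 2 and 3 therefore does not extend unchanged to compound 4, though the loss on this read-out is small. The entering group brings both a six-membered non-aromatic ring and the absence of hydrogen-bond donors, the step cannot separate these two features, and no measurement at hand accounts for the difference.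

The compounds shown leave open whether the ring itself or the methyl on its far nitrogen goes with the step, a question that unsubstituted piperazin-1-yl, morpholin-4-yl or piperidin-1-yl at this place would address. A dimethylamino group, which has no hydrogen-bond donors and no ring, would test the other feature, and a longer amine chain would show how far the open-chain tolerance reaches.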